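This account rests on a few compounds, and the source may have more. Where it says the series, first, only, none or still open, it means among the compounds named here.

Compound 1 `O=[N+]([O-])c1ccc2nn(Cc3ccccc3)c(OCCBr)c2c1`: > 256000 nM, a limit.
Compound 2 `O=[N+]([O-])c1ccc2nn(Cc3ccccc3)c(OCCCBr)c2c1`: 59000 nM.
Compound 3 `COC(=O)CCOc1c2cc([N+](=O)[O-])ccc2nn1Cc1ccccc1`: > 256000 nM, a limit.

All three compounds were tested in an ADME assay on L929 cells (Mus musculus) for cytotoxicity, read by resazurin assay, with a stated time of 48 h; a lower number here means that less compound is tolerated, a higher number that more compound is tolerated. Compound 3 gives no number, and it stands at the limit of > 256000 nM in this assay, at which 2 of the 3 values shown sit. Compound 4 `CCOC(=O)CCCOc1c2cc([N+](=O)[O-])ccc2nn1Cc1ccccc1` differs from compound 3 by (ethoxycarbonyl)methyl in place of methoxycarbonyl on a saturated chain carbon, two bonds along the chain from an oxygen on an aromatic ring. In words, this is (ethoxycarbonyl)methyl in place of methoxycarbonyl on a saturated chain carbon, two bonds along the chain from an oxygen on an aromatic ring.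

Three measured steps were made at that same place. Bromomethyl in place of bromo gave an at least 4.3-fold lower number from compound 1 to compound 2 (0.63 log units; beyond the scatter). Methoxycarbonyl in place of bromomethyl gave an at least 4.3-fold higher number from compound 2 to compound 3 (0.63 log units; beyond the scatter). Methoxycarbonyl in place of bromo gave a step that the two limits leave unreadable from compound 1 to compound 3. The first of these is the closest in kind, as the chain grows there too, but it is a single pair and it carries a different end group. For the measured compounds named here, no such pair has been measured with an ester at the chain end.

On the strength of compound 2 at 59000 nM, a modest fall is expected in this assay. A result at the limit remains possible. The expected change is an at least 2.3-fold lower number from compound 3 to compound 4 (0.36 log units; beyond the scatter). For compound 4 the estimated value is 110000 nM, with an expected range of 35000 nM to 350000 nM.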

Compound 4, concentration lethal to 50% of the cells: > 256000 nM
Compound 4: a limit, no number; the forecaster's own chance of this, stated with the estimate: 30%; middle value at least 2.3-fold (0.36 log units) from the limit.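

Compound 4 gives > 256000 nM in this assay, a limit, and so joins the compounds that yield no number: the limit of > 256000 nM in this assay, at which 3 of the 4 values shown sit. For the compounds shown here, with an ester at the chain end, the longer 3-(ethoxycarbonyl)propoxy chain therefore does not bring a measured number into the assay range, as the one extra chain carbon did in the bromide pair, and compound 2 remains the only one of the four compounds with a number. Going by these compounds alone, the one readable comparison, with ethoxycarbonyl in place of bromo, is an at least 4.3-fold higher number from compound 2 to compound 4 (0.63 log units; beyond the scatter), while the steps to compound 4 from compound 3 and from compound 1 cannot be read, as limits stand at both ends.

On these data alone, how far compound 1, compound 3 and compound 4 lie past the limit stays open, and so does whether the change from (methoxycarbonyl) to (ethoxycarbonyl) at the chain end has any effect of its own. Also open, as far as these compounds go, is how a carboxylic acid or an amine at the chain end, or a still longer chain carrying the ester, would stand in this assay.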